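This account rests on a few compounds, and the source may have more. Where it says the series, first, only, none or still open, it means among the compounds named here.

Working notes on the series.

Within the data shown here, compound 2 `O=S(=O)(NCCCNCC1COc2ccccc2O1)c1cc(C(F)(F)F)cc(C(F)(F)F)c1` gives the lowest number of the three measured so far: in a functional assay on HPAC cells (Homo sapiens) for inhibition, read by MTT assay, with a stated time of 72 h (a lower number here means a stronger inhibitor of growth, a higher number a weaker inhibitor of growth), compound 2 gives 2700 nM, while compound 1 `CC(C)(C)c1ccc(CNCCNS(=O)(=O)c2cc(C(F)(F)F)cc(C(F)(F)F)c2)cc1` gives 14000 nM and compound 3 `O=S(=O)(NCCNCc1cccc2ccccc12)c1cc(C(F)(F)F)cc(C(F)(F)F)c1` gives 18000 nM; both gaps from compound 2 lie beyond the scatter.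

The next compound, compound 4 `O=S(=O)(NCCCNCc1ccccc1)c1cc(C(F)(F)F)cc(C(F)(F)F)c1`, differs from compound 2 in one place: phenyl in place of 2,3-dihydro-1,4-benzodioxin-2-yl on a saturated chain carbon bound to an amine nitrogen. Among the measured compounds shown here, the only measured step at the same place is a 1.3-fold higher number from compound 1 to compound 3 (0.11 log units; within the scatter), which is within the scatter, though it exchanges two groups unlike those here and sits on a shorter chain, so it bears on the present step only loosely. What leaves in compound 4 is the larger group, with its second ring and its two hydrogen-bond acceptors; nothing measured shows whether those matter. Compound 2 stands apart from compound 1 and compound 3, and the present change moves compound 4 toward a plainer benzyl-type group, so a somewhat higher number is expected, of modest size: a 2.2-fold higher number from compound 2 to compound 4 (0.35 log units; beyond the scatter). For compound 4 the estimate in this assay is 6000 nM, with a range from 2500 nM to 15000 nM.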

Compound 4, concentration for 50% growth inhibition: 3200 nM
For compound 4 the middle estimate is 1.9-fold (0.27 log units) above the measured one; the measured number falls inside the stated range.
By their numbers in this assay, from the lowest: compounds 2 and 4 (each within the scatter of the next); then compounds 1 and 3 (each within the scatter of the next).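

Exchanging 2,3-dihydro-1,4-benzodioxin-2-yl for phenyl on a saturated chain carbon bound to an amine nitrogen gives a 1.2-fold higher number from compound 2 to compound 4 (0.07 log units; within the scatter) in this assay, so the second ring and the two hydrogen-bond acceptors that leave are not required to keep the number at this level on this chain. Among these compounds, the only other measured exchange at this place, a 1.3-fold higher number from compound 1 to compound 3 (0.11 log units; within the scatter), also lies within the scatter, though it sits on a shorter chain and involves different groups; neither step yet shows a group at this place changing the number. Nothing at hand bears on why the exchange in compound 4 leaves the number within the scatter.

Still open, from the compounds shown here alone, is whether the chain rather than the group at this place accounts for the lower numbers of compound 2 and compound 4, which a plain benzyl group on the shorter chain or on a longer chain would help to separate. Also open, going by these compounds, is whether a methoxy group or a carboxylic acid on the phenyl ring of compound 4 would move the number at all.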